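Tetrazole in Place of Carboxy Across Two Related Cores

The source may report more compounds than this note shows. Statements on the series, on what has been measured and on what is new or still open speak of the compounds shown alone.

Compound 1 `CC(CCCC(=O)O)c1cccc(OCc2ccc3ccccc3n2)c1` gives 500 nM in a functional assay (lung) for inhibition, with Cavia porcellus as the target; a lower number here means a stronger inhibitor, a higher number a weaker inhibitor. Compound 3 `CC(CCCc1nnn[nH]1)c1cccc(OCc2ccc3ccccc3n2)c1` carries 1H-tetrazol-5-yl in place of carboxy on a saturated chain carbon, four bonds along the chain from an aromatic carbon relative to compound 1; in this assay compound 3 gives 250 nM, a step of a 2.0-fold lower number from compound 1 to compound 3 (0.30 log units; within the scatter). Compound 2 `O=C(O)CCC(Cc1cccc(OCc2ccc3ccccc3n2)c1)c1ccccc1` differs from compound 1 in its core, and the difference between the two cores is not broken down here. In this assay compound 2 gives 56 nM, the lowest of the three numbers, beyond the scatter from both compound 3 and compound 1. Compound 4 `c1ccc(C(CCc2nnn[nH]2)Cc2cccc(OCc3ccc4ccccc4n3)c2)cc1` has not yet been measured. It carries 1H-tetrazol-5-yl in place of carboxy on a saturated chain carbon, three bonds along the chain from an aromatic carbon relative to compound 2. Among the compounds with values here, this is the same kind of change as the one made from compound 1 to compound 3, but the place differs: in the earlier pair the group sits four bonds along the chain from an aromatic carbon, here three bonds along the chain from an aromatic carbon. In this assay the expected step is a 1.6-fold lower number from compound 2 to compound 4 (0.20 log units; within the scatter), set beside the earlier one because the step of a 2.0-fold lower number from compound 1 to compound 3 (0.30 log units; within the scatter) stayed within the scatter. Compound 4 is therefore estimated at 35 nM, between 12 nM and 100 nM.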

Compound 4, half-maximal inhibitory concentration: 24 nM
Beside the measured number, compound 4's estimate is 1.5-fold (0.16 log units) above it; measured number inside the range.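

In this assay, 1H-tetrazol-5-yl in place of carboxy gives a 2.3-fold lower number from compound 2 to compound 4 (0.37 log units; beyond the scatter), a modest step in the same direction as on the core of compound 1. The two steps do not differ measurably in size, so in this series the change carries from one core to the other without a visible loss or gain: the same change on two cores in this assay, a 2.0-fold lower number (0.30 log units; within the scatter) from compound 1 to compound 3 and a 2.3-fold lower number (0.37 log units; beyond the scatter) from compound 2 to compound 4, 1.2-fold (0.07 log units) apart, within the scatter of two such steps. Within the data shown here, this rests on only two pairs, one step within the scatter and the other only modestly beyond it, and the group's place on the chain differs as well as the core, so it shows neither that the change would hold on a further core nor what underlies the step.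

The compounds shown leave open whether an acyl sulfonamide or a hydroxamic acid in the same place would follow the tetrazole. They also leave open how a longer chain carrying 1H-tetrazol-5-yl would behave on either core.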